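Swapping a carbamoyl-amino group for 4-hydroxyphenyl

The source may hold more compounds than are shown below. What is called first, only, known or untested is meant among the compounds shown, and "the series" means these compounds.

Compound 1 (`COc1cc(NC(C)CCCNC(=O)Nc2ccc(Br)cc2)c2ncccc2c1`) gives 25000 nM
Compound 2 (`COc1cc(NC(C)CCCNC(=O)NNC(=O)Nc2cccc(Cl)c2)c2ncccc2c1`) gives 93000 nM

In a functional assay on MOLT-4 cells (Homo sapiens) for inhibition, read by MTT assay, with a stated time of 72 h (on this read-out lower numbers stand for stronger inhibition and higher numbers for weaker inhibition), compound 2 has the higher of the two numbers at 93000 nM and so shows the weaker inhibition of the pair. Compound 3 (`COc1cc(NC(C)CCCNC(=O)Nc2ccc(O)cc2)c2ncccc2c1`) carries 4-hydroxyphenyl in place of ((3-chlorophenyl)carbamoyl)amino on an amide-type nitrogen. Within the data shown here, only one measured step bears on this change. It is a 3.7-fold higher number from compound 1 to compound 2 (0.57 log units; beyond the scatter) and it brought in the same ((3-chlorophenyl)carbamoyl)amino group, there in place of 4-bromophenyl. Compound 3 removes that group again and puts a substituted phenyl back on the nitrogen, so its number is expected to move down toward compound 1 at 25000 nM and to land in the same region. Among the measured compounds shown here, no measured pair shows how 4-hydroxyphenyl compares with 4-bromophenyl, so this expectation stays wide. The expected move in this assay is a 3.1-fold lower number from compound 2 to compound 3 (0.49 log units; beyond the scatter) and is of modest size. In this assay the estimate for compound 3 is 30000 nM (expected range 10000 nM to 90000 nM).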

Compound 3, half-maximal inhibitory concentration: 21000 nM
Beside the measured number, compound 3's estimate is 1.4-fold (0.15 log units) above it; the range from low to high includes it.
By their numbers in this assay, from the lowest: compounds 3 and 1 (each within the scatter of the next); then compound 2.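

In this assay, taking away ((3-chlorophenyl)carbamoyl)amino and placing 4-hydroxyphenyl on the amide-type nitrogen gives a 4.4-fold lower number from compound 2 to compound 3 (0.65 log units; beyond the scatter), so a simple substituted phenyl on this nitrogen returns the number to the region of compound 1. The new comparison is hydroxy in place of bromo on an aromatic carbon, which gives a 1.2-fold lower number from compound 1 to compound 3 (0.08 log units; within the scatter): in this read-out, these two substituents cannot be told apart, and among the three compounds only compound 2 stands apart. No supporting measurement is available to explain either step.

As far as these compounds go, it remains open whether other groups on that aromatic carbon, such as an amine or a carboxylic acid, would also leave the number in this region. From the compounds shown here alone, it is also open whether the higher number of compound 2 goes with the longer carbamoyl-amino link or with the chlorine on its ring, as these two features change together and a compound with only one of them would be needed to separate them.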